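Aryl replacement on the shared core: dropping the trifluoromethyl

The compounds below may be only part of what the source reports. "The series", "measured", "known", "first", "only" and "open" are said of these compounds alone.

Compound 1 `COc1ccc(C)cc1-c1c(C)nn(-c2nc(-c3ccc(Cl)c(Cl)c3)c(SC(C)C)s2)c1C(=O)O` gives 9500 nM in a functional assay on BJAB cells (Homo sapiens) for antiproliferative activity, with a stated time of 4 days; a higher number here means that more compound is needed for the effect, a lower number that less compound is needed. Among the compounds with values here, compound 2 `Cc1nn(-c2nc(-c3ccc(Cl)c(Cl)c3)c(SC(C)C)s2)c(C(=O)O)c1-c1ccccc1C(F)(F)F` gives 5200 nM in this assay, and the single measured step, a 1.8-fold lower number from compound 1 to compound 2 (0.26 log units; within the scatter), stays within the scatter, so the two numbers are not separated. Compound 3 `Cc1nn(-c2nc(-c3ccc(Cl)c(Cl)c3)c(SC(C)C)s2)c(C(=O)O)c1-c1ccccc1` carries hydrogen in place of trifluoromethyl on an aromatic carbon. Within the data shown here, the only step that touches this aryl group, a 1.8-fold lower number from compound 1 to compound 2 (0.26 log units; within the scatter), was itself within the scatter, so no direction can be read from it; for compound 3 a step of about scatter size is expected, a 1.3-fold higher number from compound 2 to compound 3 (0.10 log units; within the scatter). Compound 3 is estimated at 6500 nM, between 2500 nM and 17000 nM.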

Compound 3, half-maximal effective concentration: 3000 nM
Estimate against measurement, compound 3: 2.2-fold (0.34 log units) above, and the stated range covers the measured number.
By their numbers in this assay, from the lowest: compounds 3, 2 and 1 (each within the scatter of the next, the first and the last beyond it).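

In this assay, removing the trifluoromethyl does not separate the pair (a 1.7-fold lower number from compound 2 to compound 3 (0.24 log units; within the scatter)). Within the data shown here, the plain phenyl does separate from the 2-methoxy-5-methylphenyl, the first step at this position beyond the scatter, though only a modest one (a 3.2-fold lower number from compound 1 to compound 3 (0.50 log units; beyond the scatter)). No measured evidence accounts for either step. From the compounds shown here alone, compound 1 carries methoxy and methyl together, so which of the two goes with its higher number remains open. Also open, going by these compounds, is how a phenyl bearing an amine or a carboxylic acid would read here.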